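This account rests on a few compounds, and the source may have more. Where it says the series, first, only, none or still open, it means among the compounds named here.

Going by the values given here, compound 3 `Cn1c(COc2cccc(C(=O)O)c2)nc2ccc(Oc3cc(Cl)ccn3)cc21` gives 1.2 in a physicochemical assay for lipophilicity, read by LC-MS, in phosphate buffer, measured as octanol-water partition, with a stated time of 30 min, at pH 7.4, tested at 200 mM (a higher number here means a more lipophilic compound, a lower number a more polar compound), the lowest of the three numbers so far. Compound 2 `Cn1c(COc2cccc(C(=O)O)c2)nc2ccc(Oc3ccc4c(c3)OCC4)nc21` gives 1.4 in this assay, within the scatter of compound 3, while compound 1 `Cc1cc(C)cc(Oc2ccc3nc(COc4cccc(C(=O)O)c4)n(C)c3n2)c1` gives 2.3, beyond it. Among the compounds with values here, the only step measured between compounds differing in one place, a number 0.90 log units lower from compound 1 to compound 2 (beyond the scatter), exchanges one group for another on the oxygen and does not bear directly on the change made here. Compound 4 `Cc1cc(F)cnc1Oc1ccc2nc(COc3cccc(C(=O)O)c3)n(C)c2c1` differs from compound 3 in one place: 5-fluoro-3-methylpyridin-2-yl in place of 4-chloropyridin-2-yl on an oxygen on an aromatic ring. A chlorine leaves while a fluorine and a methyl enter, so the expected step is none beyond the scatter, no change at the digits printed from compound 3 to compound 4 (within the scatter). Compound 4 is therefore expected to give 1.2, in a range from 0.8 to 1.6.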

Compound 4, distribution coefficient: 1.1
For compound 4 the middle estimate is 0.10 log units above the measured one, and the stated range covers the measured number.
By their numbers in this assay, from the lowest: compounds 4, 3 and 2 (each within the scatter of the next); then compound 1.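

In this assay, the exchange of 4-chloropyridin-2-yl for 5-fluoro-3-methylpyridin-2-yl on the oxygen gives a number 0.10 log units lower from compound 3 to compound 4 (within the scatter). This is the first step shown with a pyridinyl group on both sides, and the loss of chlorine with the gain of fluorine and methyl leaves the number within the usual scatter. Since three features differ at once, this single step cannot separate what each one contributes. Whether an amine or a methoxy group on that ring would move the number beyond the scatter remains open, and nothing shown explains the result.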